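This account rests on a few compounds, and the source may have more. Where it says the series, first, only, none or still open, it means among the compounds named here.

Three compounds share one core and differ only in the aryl group on the ring nitrogen. Compound 1 `Cc1ccc(N2CCN(Cn3nc(-c4ccc5c(c4)OCCO5)oc3=S)CC2)c(C)c1` gives 28400 nM in a functional assay on HepG2 cells (Homo sapiens) for antiproliferative activity, read by MTT assay, with a stated time of 48 h; a lower number here means a stronger inhibitor, a higher number a weaker inhibitor. Compound 3 `COc1cccc(N2CCN(Cn3nc(-c4ccc5c(c4)OCCO5)oc3=S)CC2)c1` gives 21400 nM in this assay, the lowest number shown, though a 1.3-fold lower number from compound 1 to compound 3 (0.12 log units; within the scatter) keeps it within the scatter of compound 1. For compound 2 `S=c1oc(-c2ccc3c(c2)OCCO3)nn1CN1CCN(c2cccc(Cl)c2Cl)CC1` this assay reports only a limit, > 50000 nM. Compound 4 `S=c1oc(-c2ccc3c(c2)OCCO3)nn1CN1CCN(c2ccccc2Cl)CC1` brings a further aryl group: 2-chlorophenyl in place of 3-methoxyphenyl on an amine nitrogen in a ring. Among the measured compounds shown here, the steps that bear on this are an at least 2.3-fold lower number from compound 2 to compound 3 (0.36 log units; beyond the scatter) and an at least 1.7-fold higher number from compound 1 to compound 2 (0.24 log units; that floor lies within the scatter), both running against the dichlorophenyl. Since compound 4 keeps one chlorine and drops the methoxy, a modest rise is expected, roughly a 1.6-fold higher number from compound 3 to compound 4 (0.21 log units; within the scatter). Compound 4 is therefore estimated at 35000 nM, with a range from 15000 nM to 80000 nM.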

Compound 4, half-maximal inhibitory concentration: 11400 nM
The estimate for compound 4 lay 3.1-fold (0.49 log units) above the measured number, outside the stated range (below it).
By their numbers in this assay, from the lowest: compounds 4, 3 and 1 (each within the scatter of the next, the first and the last beyond it). At a limit, above all of these: compound 2.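

Hydrogen in place of chloro gives an at least 4.3-fold lower number from compound 2 to compound 4 (0.64 log units; beyond the scatter) and this step rests on a limit for compound 2, yet it shows that a single chlorine on the aryl group can clearly change the result. The 2-chlorophenyl group also gives a real gain over 2,4-dimethylphenyl, with a 2.5-fold lower number from compound 1 to compound 4 (0.40 log units; beyond the scatter) as the step. Against 3-methoxyphenyl, a 1.9-fold lower number from compound 3 to compound 4 (0.27 log units; within the scatter) is the step, so these two groups cannot be ordered. Still open, going by these compounds, is how an aryl group carrying a nitrile or a carboxylic acid would fare on this ring nitrogen. On these data alone, a benzyl group there is equally open.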